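A few compounds are considered here, and "the series" means these few. Any claim that something is new, unique, unknown or untested is made for them only; others in the source may bear on it.

Of the compounds shown here, two on a shared core have been measured so far in a functional assay on HCT-116 cells (Homo sapiens) for cytotoxicity, read by MTT assay, with a stated time of 3 days; on this read-out lower numbers stand for stronger inhibition and higher numbers for weaker inhibition. Compound 1 `CC(C)(C)c1cc2c(N/N=C/c3ccc(C(=O)O)cc3)ncnc2s1` gives 9.99 ug/mL and holds the higher of the two numbers. Compound 2 `CC(C)N1Cc2ccc(/C=N/Nc3ncnc4sc(C(C)(C)C)cc34)cc2C1` gives 0.206 ug/mL and lies lower by a gap beyond the usual scatter, but the two differ in more than one place, so that gap cannot be tied to any single group. Compound 3 `CC(C)(C)c1cc2c(N/N=C/c3ccc(O)cc3)ncnc2s1` has yet to be measured and departs from compound 1 in one place only. The change is hydroxy in place of carboxy on an aromatic carbon and amounts to hydroxy in place of carboxy on an aromatic carbon, para to a large group. Among the compounds with values here, no measured step shows what this swap does, so any expectation here is soft. With compound 1 at 9.99 ug/mL as the higher of the pair, more room lies downward than upward. The estimated 3.3-fold lower number from compound 1 to compound 3 (0.52 log units; beyond the scatter) is expected to point toward stronger inhibition, though a result within the scatter would not be surprising. In this assay the estimated value for compound 3 is 3 ug/mL with 0.7 ug/mL to 12 ug/mL as the expected range.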

Compound 3, half-maximal inhibitory concentration: 0.844 ug/mL
The estimate for compound 3 lay 3.6-fold (0.55 log units) above the measured number; the range from low to high includes it.
By their numbers in this assay, from the lowest: compound 2; then compound 3; then compound 1.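

In this assay, hydroxy in place of carboxy on an aromatic carbon, para to a large group, gives a 12-fold lower number from compound 1 to compound 3 (1.07 log units; beyond the scatter), a large step that shows this position responds strongly to the group it carries. The gap between the two earlier compounds could not be tied to any single group, whereas here the whole change rests on one place: carboxy leaves, hydroxy enters, and the rest of the structure stays the same. No measurement shown explains why this swap gives the lower number.

The compounds shown leave open whether the step comes from losing carboxy or from gaining hydroxy, as this one swap does both at once. They also leave open how a plain hydrogen, methoxy or an amine at the same place would read in this assay, and so whether hydroxy itself matters or almost any group other than carboxy would give a similar number.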